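This account rests on a few compounds, and the source may have more. Where it says the series, first, only, none or still open, it means among the compounds named here.

Compound 1 `Cc1nsc2[nH]c(SCc3ccccc3)nc12` and compound 2 `c1ccc(CSc2nc3cnsc3[nH]2)cc1` share a core and differ in one place: hydrogen in place of methyl on an aromatic carbon. In a functional assay on HFF cells (Homo sapiens) for inhibition (a higher number here means a weaker inhibitor, a lower number a stronger inhibitor), compound 1 gives 10000 nM. In this assay compound 2 gives 14000 nM. The step between them is a 1.4-fold higher number from compound 1 to compound 2 (0.15 log units; within the scatter), so the two compounds cannot be told apart on this read-out.

Compound 3 `CSc1nc2c(C)nsc2n1[C@H]1C[C@H](O)[C@@H](CO)O1` carries a different core, and how it differs from the core of compound 1 is not broken down here. In this assay compound 3 reaches only a limit of the assay, > 100000 nM, so no number is known for it.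

Compound 4 `CSc1nc2cnsc2n1[C@H]1C[C@H](O)[C@@H](CO)O1` differs from compound 3 in the same kind of change: hydrogen in place of methyl on an aromatic carbon, at a place described in the same words as for the pair of compound 1 and compound 2. Since that change made a step within the scatter from compound 1 to compound 2, the expected step from compound 3 to compound 4 is a step that the limit leaves unreadable from compound 3 to compound 4, and compound 4 is expected to sit near the limit as well because of the limit of > 100000 nM in this assay, at which 1 of the 3 values shown sits. Compound 4 is therefore estimated at 130000 nM, with a range from 50000 nM to 400000 nM.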

Compound 4, half-maximal inhibitory concentration: > 100000 nM
Compound 4 ended at the assay's limit; the forecaster's own chance of this, stated with the estimate: 80%; the middle value is on the limit's open side.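

Within the data shown here, compound 3 and compound 4 both reach only a limit in this assay and so no step between them can be read. The compounds shown leave open whether hydrogen in place of methyl changes inhibition at all on the core of compound 3, as neither compound gives a number: the limit of > 100000 nM in this assay, at which 2 of the 4 values shown sit.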